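Amide variant of compound 2: expected cell tolerance

The source may hold more compounds than are shown below. What is called first, only, known or untested is meant among the compounds shown, and "the series" means these compounds.

Going by the values given here, compound 2 `COc1cc(-c2nn(-c3cccc(NC(=O)Nc4cccc(C(F)(F)F)c4)c3)cc2-c2ccncc2)ccc1Cl` is the only member of the series with a number in a functional assay on IGROV-1 cells (Homo sapiens) for inhibition, read by sulforhodamine B assay, with a stated time of 48 h (a higher number here means that more compound is tolerated, a lower number that less compound is tolerated), where compound 2 gives 50000 nM. Among the compounds with values here, the single comparison to it is compound 1 `O=C(Nc1cccc(-n2cc(-c3ccncc3)c(-c3ccc(Cl)c(O)c3)n2)c1)Nc1cccc(C(F)(F)F)c1`. In this assay compound 1 gives only a limit of the assay, > 32500 nM. The step from compound 1 to compound 2, methyl in place of hydrogen on an oxygen on an aromatic ring, reads a step that the limit leaves unreadable from compound 1 to compound 2, as the limit of > 32500 nM in this assay, at which 1 of the 2 values shown sits, shows. Compound 3 `COc1cc(-c2nn(-c3cccc(NC(=O)c4ccccc4)c3)cc2-c2ccncc2)ccc1Cl` differs from compound 2 by phenyl in place of (3-(trifluoromethyl)phenyl)amino on a carbonyl carbon. No measured pair touches the carbonyl carbon, so none of the shown steps bears directly on this change, and the one shown step is itself unreadable. With nothing to move the expectation in either direction, compound 3 is expected to stand within the scatter of compound 2. The expected step is a 1.1-fold lower number from compound 2 to compound 3 (0.05 log units; within the scatter). Compound 3 is therefore estimated at 45000 nM, with a range from 15000 nM to 100000 nM, and a limit rather than a number is about as likely as not.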

Compound 3, concentration lethal to 50% of the cells: > 100000 nM
Compound 3: no number, only a limit (the forecaster's own chance of this, stated with the estimate: 50%); middle value at least 2.2-fold (0.34 log units) away from the limit.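

The step at the carbonyl carbon gives the series its first reading that is not blocked on both sides: in this assay, phenyl in place of (3-(trifluoromethyl)phenyl)amino gives an at least 2.0-fold higher number from compound 2 to compound 3 (0.30 log units; that floor lies within the scatter). Only a floor can be stated for this step, because compound 3 gives no number: the limit of > 100000 nM in this assay, at which 1 of the 3 values shown sits. The change removes the trifluoromethyl group, the amino nitrogen and its hydrogen-bond donor in one move, so the shown pair shows that the larger group can be exchanged at this carbonyl carbon without a drop in the number, but it cannot assign the step to any one of these parts, and the earlier step on the aromatic oxygen cannot be read.

From the compounds shown here alone, how far compound 3 actually lies from compound 2 stays open, as does whether the step at this position exceeds the scatter at all. Phenylamino on the carbonyl carbon would separate the trifluoromethyl group from the amino nitrogen, and a small alkyl chain or a morpholine there would show whether the aromatic ring matters at this position.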